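Swapping a thiophene for a phenyl on a shared core

The source may hold more compounds than are shown below. What is called first, only, known or untested is meant among the compounds shown, and "the series" means these compounds.

Compound 2 (`Oc1cccc(-c2cc(-c3ccsc3)nc(-c3cccc(Cl)c3)c2)c1`): 2510 nM
Compound 1 (`Oc1cccc(-c2cc(-c3cccc(Cl)c3)nc(-c3ccccn3)c2)c1`): "not determined" (no result reported)

Only compound 2 carries a number in a functional assay on HCT-15 cells (Homo sapiens) for cytotoxicity, read by CCK-8 assay and cell counting, with a stated time of 2 days; on this read-out lower numbers stand for stronger inhibition and higher numbers for weaker inhibition; compound 1 was made but gave no result in this assay, so compound 2 stands alone and cannot be ranked. Compound 3 (`Oc1cccc(-c2cc(-c3ccccc3)nc(-c3cccc(Cl)c3)c2)c1`) differs from compound 2 in one place: phenyl in place of thiophen-3-yl on an aromatic carbon. Going by the values given here, no measured pair in this set shows what such a change does, so no step is known in this assay. A swap of this kind usually moves the number little, so the step from compound 2 to compound 3 is expected to stay within the scatter, a 1.0-fold lower number from compound 2 to compound 3 (0.00 log units; within the scatter). Compound 3 is therefore estimated at 2500 nM, with a range from 1000 nM to 6300 nM.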

Compound 3, half-maximal inhibitory concentration: 2550 nM
Estimate against measurement, compound 3: 1.0-fold (0.01 log units) below; low and high end bracket the measured number.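

In this assay the swap gives a 1.0-fold higher number from compound 2 to compound 3 (0.01 log units; within the scatter) and so lies within the scatter. Going by these compounds alone, this is the first measured step at this position, on an aromatic carbon next to the ring nitrogen, and it shows that a six-membered aromatic ring of carbon only and a five-membered aromatic ring with sulfur cannot be told apart here. Nothing available explains why the two read alike.

From the compounds shown here alone, both groups are flat aromatic rings, so the effect of a piperidine, a carboxylic acid or a longer alkyl chain at this position remains open. Going by these compounds, whether a change elsewhere on the shared core would matter more also remains unknown.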